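Moving the Double Bond on the Chain of Compound 1

The source may hold more compounds than are shown below. What is called first, only, known or untested is meant among the compounds shown, and "the series" means these compounds.

Three compounds were measured in an assay on isolated protein for binding affinity to histone acetyltransferase KAT2B (Homo sapiens), read by isothermal titration calorimetry; a lower number here means tighter binding, a higher number weaker binding. Compound 1 `C=CCCn1c(N[C@@H]2C[C@H](c3ccccc3)CN(C)C2)nc2cc[nH]c2c1=O` gives 3410 nM. Compound 2 `CN1C[C@H](Nc2nc3cc[nH]c3c(=O)n2C)C[C@H](c2cccc(Br)c2)C1` gives 128 nM, a markedly lower number than compound 1, a gap well beyond the usual scatter. Compound 3 `CC(=O)c1cn(C[C@@H](C)CO)c2ccccc12`, built on a different scaffold, gives 45000 nM, a higher number than compound 1, again beyond the scatter. Compound 1 thus stands second highest of the three, closer to compound 3 than to compound 2.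

Compound 4 `CC=CCn1c(N[C@@H]2C[C@H](c3ccccc3)CN(C)C2)nc2cc[nH]c2c1=O` has the same atoms as compound 1 but joined differently: prop-1-en-1-yl in place of allyl on a saturated chain carbon bound to an aromatic nitrogen. The double bond of the three-carbon chain on the core nitrogen is simply shifted by one position, with no change in ring count, donors, acceptors or charge. Among the compounds with values here, no measured pair in this set shows the effect of such a shift, so the expectation rests on the small scale of the rearrangement alone. A step within the usual scatter, or at most slightly toward a higher number, is expected from compound 1 to compound 4, a 1.2-fold higher number from compound 1 to compound 4 (0.07 log units; within the scatter). Compound 4 is therefore estimated at 4000 nM in this assay, with a range from 1500 nM to 12000 nM.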

Compound 4, dissociation constant: 3040 nM
Compound 4: the middle estimate sits 1.3-fold (0.12 log units) above what was measured; measured number inside the range.
By their numbers in this assay, from the lowest: compound 2; then compounds 4 and 1 (each within the scatter of the next); then compound 3.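

In this assay, moving the double bond along the chain gives a 1.1-fold lower number from compound 1 to compound 4 (0.05 log units; within the scatter) and nothing more, so this assay does not tell but-3-en-1-yl from but-2-en-1-yl at this place on the shared core. Within the data shown here, this is the first step in the set between two compounds that differ in one place, and it shows that, for this one shift, where the double bond sits in the chain leaves the binding number within the usual scatter while the count of heavy atoms, the count of double bonds and the net charge all stay the same. No supporting measurement is available to explain why the two chains read alike.

The compounds shown leave open whether the double bond is needed at all, since a saturated butyl chain would test that directly, and whether a shorter chain such as ethyl or a longer chain such as hexyl would stay within the same range. They also leave open what a group of another kind at the end of the chain, such as an amine or a carboxylic acid, would do to the binding number at this place.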